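Replacing the Fluorinated Phenyl with Cyclopentyl

A few compounds are considered here, and "the series" means these few. Any claim that something is new, unique, unknown or untested is made for them only; others in the source may bear on it.

In a physicochemical assay for solubility, read by HPLC, using the shake flask method, in phosphate buffer, with a stated time of 20 h, at pH 6.5 (a lower number here means a less soluble compound, a higher number a more soluble compound), compound 1 `Fc1ccc(-c2nc3c(C4CCNCC4)nccc3[nH]2)cc1F` gives 200000 nM. Compound 2 `CN1CCN(CC2CCN(c3nccc4[nH]c(-c5ccc(F)c(C(F)(F)F)c5)nc34)CC2)CC1` gives 165000 nM, and compound 3 `CN1CCN(CC2CCN(c3nccc4[nH]c(-c5cc(F)cc(C(F)(F)F)c5)nc34)CC2)CC1` gives 165000 nM. Compound 3 thus stands level with compound 2 and within the scatter of compound 1. Compound 4 `CN1CCN(CC2CCN(c3nccc4[nH]c(C5CCCC5)nc34)CC2)CC1` carries cyclopentyl in place of 3-fluoro-5-(trifluoromethyl)phenyl on an aromatic carbon. Within the data shown here, the one measured step, no change at the digits printed from compound 2 to compound 3 (within the scatter), bears on this only indirectly, since no measured step removes the phenyl group. The three values nonetheless sit within the scatter of each other. The expected step, a 1.2-fold higher number from compound 3 to compound 4 (0.06 log units; within the scatter), is therefore none beyond the scatter. Compound 4 is estimated at 190000 nM, with an expected range from 110000 nM to 320000 nM.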

Compound 4, solubility: < 5000 nM
Compound 4: a limit, no number; the forecaster's own chance of this, stated with the estimate: 20%; at least 38-fold (1.57 log units) between middle value and limit.
By their numbers in this assay, from the lowest: compounds 2, 3 and 1 (each within the scatter of the next). At a limit, below all of these: compound 4.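

Compound 4 reads < 5000 nM in this assay, a limit and not a number: the limit of < 5000 nM in this assay, at which 1 of the 4 values shown sits. Cyclopentyl in place of 3-fluoro-5-(trifluoromethyl)phenyl gives an at least 33-fold lower number from compound 3 to compound 4 (1.51 log units; beyond the scatter), and in place of 4-fluoro-3-(trifluoromethyl)phenyl it gives an at least 33-fold lower number from compound 2 to compound 4 (1.51 log units; beyond the scatter). The read-out thus responds to what sits on this aromatic carbon between two ring nitrogen atoms, which the exchange of one fluorinated phenyl for the other, no change at the digits printed from compound 2 to compound 3 (within the scatter), did not show.

On these data alone, how far compound 4 lies under its limit stays unknown. As far as these compounds go, whether unsubstituted phenyl, cyclohexyl or a ring carrying an amine would read like compound 3 or like compound 4 remains open.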